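Fixing one stereocentre on a pyrrole-bearing amide

A few compounds are considered here, and "the series" means these few. Any claim that something is new, unique, unknown or untested is made for them only; others in the source may bear on it.

Compound 1 `O=C(Nc1ccc(-c2cscn2)cc1)[C@@H]1CCCN(Cc2ccc(F)c(F)c2)C1` gives 6000 nM in a functional assay on A-375 cells (Homo sapiens) for antiproliferative activity; on this read-out higher numbers stand for weaker inhibition and lower numbers for stronger inhibition
Compound 2 `O=C(Nc1ccc(-c2ccc[nH]2)cc1)C1CCCN(Cc2ccc(F)c(F)c2)C1` gives 360 nM in this assay

Of these two compounds, compound 2 at 360 nM has the lower number, and the gap to compound 1 at 6000 nM lies beyond the scatter. Compound 3 `O=C(Nc1ccc(-c2ccc[nH]2)cc1)[C@@H]1CCCN(Cc2ccc(F)c(F)c2)C1` has the same atoms and bonds as compound 2. The only difference is the two compounds have the same atoms and bonds; at least one stereo element is drawn with a configuration in one of them and without one in the other: 1 of 1 stereo elements differ; a stereocentre at a saturated ring carbon is drawn without a configuration in compound 2 and R in compound 3 in that a stereocentre at a saturated ring carbon is drawn without a configuration in compound 2 and R in compound 3. For the measured compounds named here, no measured pair isolates this change, so the evidence is thin. Going by the values given here, compound 1 differs elsewhere but shares the drawn configuration, and its 6000 nM is the only guide, pointing weakly towards a higher number. The expected change is a 3.3-fold higher number from compound 2 to compound 3 (0.52 log units; beyond the scatter) as a moderate loss, though a result within the scatter remains possible. For compound 3 the estimate is 1200 nM with an expected range from 250 nM to 6000 nM in this assay once measured.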

Compound 3, half-maximal inhibitory concentration: 18000 nM
Estimate against measurement, compound 3: 15-fold (1.18 log units) below, and the stated range ends below it.
By their numbers in this assay, from the lowest: compound 2; then compound 1; then compound 3.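

For the compounds shown here, with atoms and bonds unchanged, this assay records a 50-fold higher number from compound 2 to compound 3 (1.70 log units; beyond the scatter), so the configuration drawn at this saturated ring carbon has a large bearing on the read-out, and only one thing separates the pair: the fact that one of compounds 2 and 3 is drawn with a defined configuration and the other without, at the place where they differ With R drawn in both compounds, 1H-pyrrol-2-yl in place of 1,3-thiazol-4-yl gives a 3.0-fold higher number from compound 1 to compound 3 (0.48 log units; beyond the scatter), a modest step. The low number of compound 2 therefore does not carry over to the R form of the pyrrole compound.

The compounds shown leave open how the S form would read and, with that, which configuration accounts for the number of compound 2. Also open, as far as these compounds go, is whether a furan-2-yl group or a methyl group on the pyrrole nitrogen would follow the same trend at this stereocentre.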